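A Phenyl for a Pyridinyloxy Group on the Saturated Ring

The compounds below may be only part of what the source reports. "The series", "measured", "known", "first", "only" and "open" are said of these compounds alone.

Compound 1 `O=C(NCc1ccccc1)Nc1[nH]nc(-c2ccccn2)c1Cl` — > 400 mL.min-1.g-1
Compound 2 `O=C(Nc1cc(-c2ccccn2)n[nH]1)N1CCC(Oc2ccccn2)CC1` — 67.3 mL.min-1.g-1
Compound 3 `COc1ccc(C(=O)Nc2[nH]nc(-c3ccccn3)c2C2CC2)cc1` — > 100 mL.min-1.g-1

In an ADME assay on liver (Mesocricetus auratus) for metabolic stability, using microsomes (a lower number here means slower removal, a higher number faster removal of the compound), compound 2 gives 67.3 mL.min-1.g-1. For the measured compounds named here, that is the only number among the three values shown; the other two are limits of the assay. For compound 1 the value > 400 mL.min-1.g-1 is a limit (the limit of > 400 mL.min-1.g-1 in this assay, at which 1 of the 3 values shown sits). For compound 3 the value > 100 mL.min-1.g-1 is likewise a limit (the limit of > 100 mL.min-1.g-1 in this assay, at which 1 of the 3 values shown sits). So compound 2 stands alone as a measured number, with no comparison to another number possible.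

Compound 4 `O=C(Nc1cc(-c2ccccn2)n[nH]1)N1CCC(c2ccccc2)CC1` has not yet been measured. It differs from compound 2 in one place: phenyl in place of (pyridin-2-yl)oxy on a saturated ring carbon. Going by the values given here, no step between measured compounds is available here, so the size of this change cannot be read from the data. A modest rise in clearance in this assay is expected, though a result within the usual scatter of compound 2 would not surprise. Compound 4 is estimated at 120 mL.min-1.g-1, between 50 mL.min-1.g-1 and 300 mL.min-1.g-1. The expected step of a 1.8-fold higher number from compound 2 to compound 4 (0.25 log units; within the scatter) is estimated as small to moderate, upward, with a real chance that the assay reports only a limit.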

Compound 4, intrinsic clearance in microsomes: 216 mL.min-1.g-1
Estimate against measurement, compound 4: 1.8-fold (0.26 log units) below; measured number inside the range.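

For the compounds shown here, for this assay the first step between two numbers rather than limits is a 3.2-fold higher number from compound 2 to compound 4 (0.51 log units; beyond the scatter) and it comes from phenyl in place of (pyridin-2-yl)oxy on a saturated ring carbon. The group three ring bonds from the ring nitrogen therefore moves this read-out beyond the scatter while the rest of the molecule stays the same, and of this pair compound 2 has the lower number. Nothing measured here gives a cause for this step.

From the compounds shown here alone, whether an amine, a carboxylic acid or a longer chain at this ring carbon would give a number nearer that of compound 2 or that of compound 4 remains open. Also open is whether the same change would give a similar step on another core, as only one such pair is shown.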